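A Second Fluorine on the Shared Core

The source may hold more compounds than are shown below. What is called first, only, known or untested is meant among the compounds shown, and "the series" means these compounds.

Measured in an in vitro assay on HEK385-7 cells for displacement of a labelled ligand from prostaglandin D2 receptor 2 (Homo sapiens); on this read-out higher numbers stand for weaker inhibition and lower numbers for stronger inhibition:
compound 1 `O=C(O)Cc1sc(C(c2ccccc2)c2ccc(F)cc2)nc1-c1ccc(Cl)cc1`: 17 nM
compound 2 `O=C(O)Cc1sc(C(c2ccc(F)cc2)c2ccc(F)cc2)nc1-c1ccc(Cl)cc1`: 9.7 nM
compound 3 `O=C(O)Cc1sc(C(c2ccccc2)c2ccccc2)nc1-c1cccc(F)c1`: 2.9 nM

Compound 3 gives the lowest number of the three and is the most potent here, since its steps to compound 2 and compound 1 both lie beyond the scatter. How the core of compound 3 differs from that of compound 1 is not broken down here. Between compound 1 and compound 2 the change is fluoro in place of hydrogen on an aromatic carbon, and it made a 1.8-fold lower number from compound 1 to compound 2 (0.24 log units; within the scatter).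

Compound 4 `O=C(O)Cc1sc(C(c2ccccc2)c2ccccc2)nc1-c1ccc(F)c(F)c1` has not yet been measured in this assay. It differs from compound 3 by fluoro in place of hydrogen on an aromatic carbon. This is the same kind of change as from compound 1 to compound 2, but not the same: here the entering fluoro sits ortho to a fluoro group, which the earlier place lacked. Because a 1.8-fold lower number from compound 1 to compound 2 (0.24 log units; within the scatter) stayed within the scatter, only a small step is expected, a 1.2-fold lower number from compound 3 to compound 4 (0.08 log units; within the scatter). Compound 4 is therefore estimated at 2.4 nM, with a range from 1 nM to 6 nM.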

Compound 4, half-maximal inhibitory concentration: 4.1 nM
For compound 4 the middle estimate is 1.7-fold (0.23 log units) below the measured one; low and high end bracket the measured number.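

In this assay, fluoro in place of hydrogen on an aromatic carbon gave a 1.4-fold higher number from compound 3 to compound 4 (0.15 log units; within the scatter), so the change again made only a small step on this second core. Set beside the earlier case, the two steps cannot be told apart: the same change on two cores in this assay, a 1.8-fold lower number (0.24 log units; within the scatter) from compound 1 to compound 2 and a 1.4-fold higher number (0.15 log units; within the scatter) from compound 3 to compound 4, 2.5-fold (0.39 log units) apart, within the scatter of two such steps. This shows that the change stayed small on both cores, but it does not show a real effect on either one, and two pairs cannot establish a rule for the whole series.

The compounds shown leave open whether a methoxy or trifluoromethyl group entering at the same place would also make only a small step. Going by these compounds, it also remains open whether the fluoro step stays this small on other cores.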